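Diethylamino in Place of Dimethylamino on a Shared Core

A few compounds are considered here, and "the series" means these few. Any claim that something is new, unique, unknown or untested is made for them only; others in the source may bear on it.

Three compounds with a shared core were tested in an assay on isolated protein for inhibition of DNA topoisomerase 1 (Homo sapiens), with a stated time of 30 min, tested at 20 uM; a lower number here means a weaker effect, a higher number a stronger effect of the compound at the concentration tested. Compound 1 `CN(C)c1ccc2nc(-c3cccc4ccccc34)[nH]c(=O)c2c1` gives 2.4% in this assay. Compound 2 `COc1cccc(-c2nc3ccc(C)cc3c(=O)[nH]2)c1` gives 0%, and compound 3 `Cc1ccc2c(=O)[nH]c(-c3ccccc3N(C)C)nc2c1` gives 5.3%. On these numbers compound 1 sits between the other two, but its gaps to compound 2 and to compound 3 both lie within the usual scatter of such measurements, so the three cannot be told apart and each shows little effect at the concentration tested.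

Compound 4 `CCN(CC)c1ccc2nc(-c3cccc4ccccc34)[nH]c(=O)c2c1` has not yet been measured. It differs from compound 1 in one place: diethylamino in place of dimethylamino on an aromatic carbon. A group of the same kind, only slightly larger, takes the place of the old one. Among the compounds with values here, no measured pair shows how a change of this sort acts in this assay, and every value so far is low, so the step is expected to be small and not beyond the scatter, in no particular direction. Compound 4 is therefore expected to give about 3% in this assay, with a range from 0% to 12%. The step this estimate means, a number 0.6 percentage points higher from compound 1 to compound 4 (within the scatter), is expected to stay within the scatter.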

Compound 4, a percentage reported as inhibition, at one concentration (the size of the read-out at that concentration, not a potency): 25.5%
Compound 4: middle estimate off by 22.5 percentage points, on the low side; measured number outside the range, above it.
By their numbers in this assay, from the lowest: compounds 2, 1 and 3 (each within the scatter of the next); then compound 4.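

In this assay, within the data shown here, diethylamino in place of dimethylamino on this aromatic carbon gives a number 23.1 percentage points higher from compound 1 to compound 4 (beyond the scatter), the first step that stands beyond the scatter, so this position is not indifferent to the group it carries. The two groups match in what is counted here, each with one nitrogen, no ring, no net charge and no hydrogen-bond donors, and they differ in carbon count, with four carbons entering where two leave. No measurement here bears on why the number rises.

From the compounds shown here alone, whether the rise continues with a longer chain, as in dipropylamino, or survives with the nitrogen tied into a ring, as in piperidine, remains open. Also open, going by these compounds, is what a simple unsubstituted amine would give here, and whether diethylamino would act the same way in compound 3, which also carries dimethylamino.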